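Swapping Methoxy for Sulfamoylmethyl on a Chloro Compound

The source may report more compounds than this note shows. Statements on the series, on what has been measured and on what is new or still open speak of the compounds shown alone.

For the measured compounds named here, in a functional assay on P388 cells (Mus musculus) for antiproliferative activity (a higher number here means a weaker inhibitor, a lower number a stronger inhibitor), compound 2 `COc1ccc(S(=O)(=O)Nc2cccc3c(Cl)c[nH]c23)cc1` gives 0.76 ug/mL, the higher of the two numbers so far, while compound 1 `COc1ccc(S(=O)(=O)Nc2cccc3c(C#N)c[nH]c23)cc1` gives 0.17 ug/mL. Compound 3 `NS(=O)(=O)Cc1ccc(S(=O)(=O)Nc2cccc3c(Cl)c[nH]c23)cc1` keeps the chloro group of compound 2 but carries sulfamoylmethyl in place of methoxy on an aromatic carbon. Going by the values given here, the only measured step, a 4.5-fold higher number from compound 1 to compound 2 (0.65 log units; beyond the scatter), put chloro in place of cyano, a different swap, so it shows only how large one change can be. No step beyond the scatter is expected, and the estimated change is a 1.5-fold lower number from compound 2 to compound 3 (0.18 log units; within the scatter). In this assay compound 3 is estimated at 0.5 ug/mL, with a range of 0.1 ug/mL to 2.5 ug/mL.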

Compound 3, half-maximal inhibitory concentration: 0.15 ug/mL
Compound 3: the middle estimate sits 3.3-fold (0.52 log units) above what was measured, within the range that was stated.
By their numbers in this assay, from the lowest: compounds 3 and 1 (each within the scatter of the next); then compound 2.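

This gives the first view of the aromatic carbon para to a large group: sulfamoylmethyl in place of methoxy gives a 5.1-fold lower number from compound 2 to compound 3 (0.70 log units; beyond the scatter) in this assay. The position therefore accepts a group of 5 heavy atoms instead of 2, one that brings a hydrogen-bond donor, and the number falls rather than rises. Nothing measured here explains this step.

The compounds shown leave open whether a carboxylic acid or an aminomethyl group at this position would act alike. They also leave open whether sulfamoylmethyl would give a similar step on compound 1, which carries the nitrile.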